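The source may hold more compounds than are shown below. What is called first, only, known or untested is meant among the compounds shown, and "the series" means these compounds.

Measured in an ADME assay on microsomes from liver (Mus musculus) for metabolic stability, read by LC-MS, with a stated time of 10 min, tested at 0.5 uM; a higher number here means that more of the compound is left, a lower number that less of the compound is left:
- compound 1 `CC(C)N1CCN(CCCN(C[C@H]2Cc3ccccc3CN2)[C@H]2CCCc3cccnc32)CC1` gives 58%
- compound 2 `NC(=O)N1CCN(CCCN(C[C@H]2Cc3ccccc3CN2)[C@H]2CCCc3cccnc32)CC1` gives 42%

For the measured compounds named here, compound 2 is the lower of the two, at 42% in this assay (the lowest number so far), and compound 1 is the nearest and only neighbour.

Next in the series is compound 3 `c1ccc2c(c1)CN[C@@H](CN(CC[C@H]1CCCNC1)[C@H]1CCCc3cccnc31)C2`, which has piperidin-3-yl in place of (4-carbamoylpiperazin-1-yl)methyl on a saturated chain carbon, two bonds along the chain from an amine nitrogen.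

Going by the values given here, only one measured step bears on this change: a number 16 percentage points lower from compound 1 to compound 2 (beyond the scatter). That modest step altered a group on the ring that now leaves altogether, so it is only a loose guide. Among the compounds with values here, no measured compound lacks that ring, so the direction is uncertain. A modest rise is expected in this assay, of about the same size as that step. The estimated change is a number 12 percentage points higher from compound 2 to compound 3 (beyond the scatter). For compound 3 the estimate is 54% (expected range 34% to 74%).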

Compound 3, percent of the compound remaining: 56%
Compound 3: the middle estimate sits 2 percentage points below what was measured, within the range that was stated.
By their numbers in this assay, from the lowest: compound 2; then compounds 3 and 1 (each within the scatter of the next).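

Replacing (4-carbamoylpiperazin-1-yl)methyl with piperidin-3-yl on a saturated chain carbon, two bonds along the chain from an amine nitrogen, gives a number 14 percentage points higher from compound 2 to compound 3 (beyond the scatter) in this assay. Set against the isopropyl-bearing group, the same replacement gives a number 2 percentage points lower from compound 1 to compound 3 (within the scatter), so at this position the piperazine ring can leave without a difference beyond the scatter from compound 1, and the result does not depend on that ring being present. No measurement at hand explains either step.

From the compounds shown here alone, it remains open whether an isopropyl or carbamoyl group on the piperidine nitrogen would repeat the earlier step, a number 16 percentage points lower from compound 1 to compound 2 (beyond the scatter), now on the smaller ring. Also unresolved is how this assay would respond to the opposite configuration at the piperidin-3-yl stereocentre, to a piperidin-4-yl group, or to an open-chain dimethylamino group at this position.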